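The compounds below may be only part of what the source reports. "The series", "measured", "known", "first", "only" and "open" are said of these compounds alone.

Measured in an in vivo ADME assay on the whole organism (plasma, strain Sprague-Dawley) for pharmacokinetics, with Rattus norvegicus as the target; on this read-out higher numbers stand for fast clearance and lower numbers for slow clearance:
- compound 1 `Cc1cc([C@@H]2C[C@H]2C(=O)O)ccc1-c1noc(-c2ccc(OC(C)C)c(C(F)(F)F)c2)n1`: 2.4 mL/min/kg
- compound 2 `Cc1cc([C@@H]2C[C@H]2C(=O)O)ccc1-c1noc(-c2ccc(OC(C)C)c(C#N)c2)n1`: "not determined" (no result reported); 3.4 mL/min/kg; 1 mL/min/kg (3 entries)

Within the data shown here, compound 1 gives 2.4 mL/min/kg, the only single number available for either measured compound. That number sits within the spread seen in the several entries of compound 2 in this assay, "not determined" (no result reported); 3.4 mL/min/kg; 1 mL/min/kg (3 entries), so repeat entries for a closely related compound already vary widely.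

The next compound is compound 3 `Cc1cc(CCC(=O)O)ccc1-c1noc(-c2ccc(OC(C)C)c(C(F)(F)F)c2)n1`. It has 2-carboxyethyl in place of 2-carboxycyclopropyl on an aromatic carbon, so the three-membered ring is gone: 2-carboxyethyl in place of 2-carboxycyclopropyl on an aromatic carbon.

Among the measured compounds shown here, no measured pair shows this change, so the expectation rests on judgement and stays loose. A modest rise in this assay is expected, of about the size of the estimated 1.7-fold higher number from compound 1 to compound 3 (0.22 log units; within the scatter), and it may not clear the usual scatter by much.

For compound 3 the expected clearance is 4 mL/min/kg, with an estimated range of 1.5 mL/min/kg to 12 mL/min/kg.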

Compound 3, clearance: 8.7 mL/min/kg
Beside the measured number, compound 3's estimate is 2.2-fold (0.34 log units) below it, and the stated range covers the measured number.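

In this assay, putting 2-carboxyethyl in place of 2-carboxycyclopropyl on this aromatic carbon gives a 3.6-fold higher number from compound 1 to compound 3 (0.56 log units; beyond the scatter). Among these compounds, this is the first readable step at this position, and it shows that the open chain, which has no ring and no defined stereocentres, moves clearance towards the fast side. The step should still be read with some care, since repeat entries for a closely related compound already vary widely: the several entries of compound 2 in this assay, "not determined" (no result reported); 3.4 mL/min/kg; 1 mL/min/kg (3 entries)

The compounds shown leave open whether the rise comes from losing the three-membered ring itself or from losing the fixed arrangement of its two stereocentres. They also leave open how clearance would respond at this position to a longer chain ending in the carboxylic acid, or to a primary amide in place of that acid.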